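The source may report more compounds than this note shows. Statements on the series, on what has been measured and on what is new or still open speak of the compounds shown alone.

Compound 1 `COC(=O)c1ccc(NCc2cncn2Cc2cccc(Br)c2)cc1-c1ccccc1` and compound 2 `Clc1ccc(NCc2cncn2Cc2ccc(-c3ccccc3)cc2)cc1-c1ccccc1` share a core and were both tested in a toxicity assay on NIH3T3 cells (Mus musculus) for cytotoxicity, read by resazurin assay; a lower number here means that less compound is needed, a higher number that more compound is needed for the effect. In this assay compound 1 gives > 10000 nM, a limit of the assay and not a number. In this assay compound 2 gives > 1000 nM, which is likewise a limit of the assay and not a number. Compound 2 thus stands at a limit, and of the two values shown one sits at the limit of > 1000 nM in this assay, at which 1 of the 2 values shown sits, and the other at the limit of > 10000 nM in this assay, at which 1 of the 2 values shown sits, so no number is known for either compound.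

Compound 3 `CN(C)C(=O)c1ccc(NCc2cncn2Cc2ccc(-c3ccccc3)cc2)cc1-c1ccccc1` is the next compound to be measured in this assay. It differs from compound 2 in one place: dimethylcarbamoyl in place of chloro on an aromatic carbon. Within the data shown here, no step between two measured compounds is available, so the expected size of the change in this assay rests on the structural change alone; since both compounds shown sit at limits, no shift beyond the usual scatter is anticipated, and the expected step that the limit leaves unreadable from compound 2 to compound 3 is small. Compound 3 is therefore estimated to give 20000 nM, within a range from 5000 nM to 80000 nM, most likely again reported as a limit.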

Compound 3, half-maximal effective concentration: > 1000 nM
Compound 3 gave a limit, no number (the forecaster's own chance of this, stated with the estimate: 75%); the middle value is on the limit's open side.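

Compound 2 and compound 3 both sit at a limit in this assay, so no step can be read for dimethylcarbamoyl in place of chloro: the limit of > 1000 nM in this assay, at which 2 of the 3 values shown sit.

The compounds shown leave open how much of any of them is needed for the effect in this assay, and whether this exchange alters that amount at all.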